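Ether to thioether linker change in the series

The source may hold more compounds than are shown below. What is called first, only, known or untested is meant among the compounds shown, and "the series" means these compounds.

Compound 1 `Nc1cc(N)c2nc(-c3ccccc3)c(Oc3ccc(Cl)c(Cl)c3)nc2c1` carries a 3,4-dichlorophenoxy group on the shared core. In a functional assay on CCRF-CEM cells (Homo sapiens) for inhibition, read by sulforhodamine B assay, with a stated time of 48 h (on this read-out lower numbers stand for higher toxicity in this test and higher numbers for lower toxicity in this test), compound 1 reports only a limit, < 100000 nM, and no number. Compound 3 `CCOC(=O)[C@H](CCC(=O)O)NC(=O)c1ccc(Sc2nc3cc(N)cc(N)c3nc2-c2ccccc2)cc1` likewise reaches only a limit, < 100000 nM. Compound 1 thus stands at the limit of < 100000 nM in this assay, at which 2 of the 3 values shown sit, so it cannot be ranked numerically. Within the data shown here, compound 2 `Nc1cc(N)c2nc(-c3ccccc3)c(NCc3ccc(Cl)c(Cl)c3)nc2c1` is the single measured compound with a number, giving 17400 nM in this assay. Compound 4 `Nc1cc(N)c2nc(-c3ccccc3)c(Sc3ccc(Cl)c(Cl)c3)nc2c1` differs from compound 1 by (3,4-dichlorophenyl)sulfanyl in place of 3,4-dichlorophenoxy on an aromatic carbon. Among the measured compounds shown here, no measured step between related compounds is available, and compound 3, which also bears a sulfanyl link, sits at the same limit as compound 1. The change is therefore expected to give no step beyond the scatter in this assay, and compound 4 is estimated at 60000 nM (range 15000 nM to 150000 nM). The expected step is a step that the limit leaves unreadable from compound 1 to compound 4.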

Compound 4, concentration lethal to 50% of the cells: < 100000 nM
Compound 4: a limit, no number; the forecaster's own chance of this, stated with the estimate: 55%; the middle value is on the limit's open side.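

Compound 1 and compound 4 each give only a limit in this assay, so no step between them can be read: the limit of < 100000 nM in this assay, at which 3 of the 4 values shown sit.

Going by these compounds, whether (3,4-dichlorophenyl)sulfanyl and 3,4-dichlorophenoxy differ at all on the shared core in this assay stays open.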